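Second methoxy on a thione inhibitor of alpha glucosidase

The source may report more compounds than this note shows. Statements on the series, on what has been measured and on what is new or still open speak of the compounds shown alone.

Compound 1: `COc1cc(/C=C2\SC(=O)NC2=O)cc(OC)c1OCN1C(=O)c2ccccc2C1=O` — > 100000 nM
Compound 2: `COc1cc(/C=C2\SC(=S)NC2=O)ccc1OCN1C(=O)c2ccccc2C1=O` — 16100 nM

Of the compounds shown here, two have been tested in an assay on isolated protein for inhibition of Alpha glucosidase (Homo sapiens), read by spectrophotometry, with stated times of 15 min and 30 min; a higher number here means a weaker inhibitor, a lower number a stronger inhibitor. Compound 1 reaches only a limit of the assay, > 100000 nM, so no number is attached to it; (the limit of > 100000 nM in this assay, at which 1 of the 2 values shown sits). Among the measured compounds shown here, compound 2 is the one compound with a true number, giving 16100 nM in this assay, and it therefore stands as the sole fixed point against which anything new can be read.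

Compound 3, `COc1cc(/C=C2\SC(=S)NC2=O)cc(OC)c1OCN1C(=O)c2ccccc2C1=O`, has not yet been measured. It differs from compound 2 in one place: methoxy in place of hydrogen on an aromatic carbon. For the measured compounds named here, no pair of measured compounds shows what this change does on its own, so its effect can only be guessed. The move is expected to stay close to the starting point, perhaps leaning towards a weaker inhibitor, with a step of a 1.6-fold higher number from compound 2 to compound 3 (0.19 log units; within the scatter) in this assay. Compound 3 is accordingly estimated at 25000 nM, within a range from 8000 nM to 100000 nM, with some chance that only a limit is reported.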

Compound 3, half-maximal inhibitory concentration: 39800 nM
The estimate for compound 3 lay 1.6-fold (0.20 log units) below the measured number; the measured number falls inside the stated range.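

In this assay, among the compounds shown here, the step of a 2.5-fold higher number from compound 2 to compound 3 (0.39 log units; beyond the scatter) gives the first reading of a new methoxy group on the ring, ortho to a large group and meta to a methoxy group: the added methoxy makes the inhibitor modestly weaker, and the compound still gives a measurable number. With both methoxy groups kept, the other single change, a group of 8 heavy atoms holding 2 sulfur in place of one holding 2 oxygen, gives an at least 2.5-fold lower number from compound 1 to compound 3 (0.40 log units; beyond the scatter), so the group carrying more sulfur keeps a measurable number in this pattern of substitution. The value of compound 1 in this assay is a limit and not a number, which leaves the true size of that step unknown: the limit of > 100000 nM in this assay, at which 1 of the 3 values shown sits.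

The compounds shown leave open whether the weakening belongs to methoxy in particular or would also appear with another group at this place, such as a fluorine, a hydroxyl or an ethoxy. They also leave open whether the group holding 2 sulfur would show a similar advantage in a compound with hydrogen at this position.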